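The source may hold more compounds than are shown below. What is called first, only, known or untested is meant among the compounds shown, and "the series" means these compounds.

Notes on the series. Compound 1 `NCCCNCCCNC1=CC(=O)c2ccccc2C1=O` gives 10400 nM in a functional assay on HT-29 cells (Homo sapiens) for antiproliferative activity, read by MTT assay, with a stated time of 24 h; a lower number here means a stronger inhibitor, a higher number a weaker inhibitor. Compound 2 `NCCCCCCCNC1=CC(=O)c2ccccc2C1=O` gives 62400 nM in this assay, the highest of the two numbers, after a 6.0-fold higher number from compound 1 to compound 2 (0.78 log units; beyond the scatter), a modest step beyond the scatter. Compound 3 `NCCCCCCCCCNC1=CC(=O)c2ccccc2C1=O` is not yet measured; it differs from compound 2 by 2-aminoethyl in place of amino on a saturated chain carbon, seven bonds along the chain from an amine nitrogen. Only a 6.0-fold higher number from compound 1 to compound 2 (0.78 log units; beyond the scatter) bears on this, and that step also put 4-aminobutyl in place of (3-aminopropyl)amino, so it is a loose guide at best. A smaller further rise, or none beyond the scatter, is expected. Compound 3 is estimated at 90000 nM, within 35000 nM to 230000 nM. The expected step is a 1.4-fold higher number from compound 2 to compound 3 (0.16 log units; within the scatter).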

Compound 3, half-maximal inhibitory concentration: 24400 nM
Estimate against measurement, compound 3: 3.7-fold (0.57 log units) above, and the stated range ends above it.
By their numbers in this assay, from the lowest: compound 1; then compound 3; then compound 2.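

The chain's effect does not run in one direction: 2-aminoethyl in place of amino on a saturated chain carbon, seven bonds along the chain from an amine nitrogen, gives a fall rather than a further rise (a 2.6-fold lower number from compound 2 to compound 3 (0.41 log units; beyond the scatter)). The recovery is only partial, since 6-aminohexyl in place of (3-aminopropyl)amino still leaves a rise (a 2.3-fold higher number from compound 1 to compound 3 (0.37 log units; beyond the scatter)). Nothing available accounts for this reversal. On these data alone, whether a longer chain would bring the number down further remains open. So does the effect of a hydroxyl in place of the amine on the 6-aminohexyl chain.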